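A few compounds are considered here, and "the series" means these few. Any claim that something is new, unique, unknown or untested is made for them only; others in the source may bear on it.

Series notes. Compound 1 `COc1nc2ccc(Br)cc2cc1C(c1ccccc1)n1cc(-c2ccccc2F)nn1` gives 3.97% in an ADME assay on HEK293 cells (Homo sapiens) for cytotoxicity, read by sulforhodamine B assay, with a stated time of 48 h, tested at 10 uM; on this read-out higher numbers stand for more inhibition at the one concentration tested (going by the name of the read-out) and lower numbers for less inhibition. Compound 2 `COc1nc2ccc(Br)cc2cc1C(c1ccccc1)n1cc(-c2ccc(OC(F)(F)F)cc2)nn1` gives 5.8% in this assay; compound 2 stands alongside compound 1, the step of a number 1.8 percentage points higher from compound 1 to compound 2 (within the scatter) lying within the scatter. Compound 3 `COc1nc2ccc(Br)cc2cc1C(c1ccccc1)n1cc(-c2cccc(F)c2)nn1` differs from compound 2 in one place: 3-fluorophenyl in place of 4-(trifluoromethoxy)phenyl on an aromatic carbon. Among the compounds with values here, the only measured step bearing on this aromatic carbon is the one from compound 1 to compound 2, and it stayed within the scatter, so for compound 3 no step beyond the scatter is expected in this assay, with a number 0.8 percentage points lower from compound 2 to compound 3 (within the scatter) as the expected shift. Compound 3 is therefore estimated at 5%, range -5% to 15%.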

Compound 3, a percentage reported as inhibition, at one concentration (the size of the read-out at that concentration, not a potency): 6.84%
Compound 3: middle estimate off by 1.8 percentage points, on the low side, within the range that was stated.
By their numbers in this assay, from the lowest: compounds 1, 2 and 3 (each within the scatter of the next).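

In this assay, the change to 3-fluorophenyl on this aromatic carbon reads as a number 1 percentage points higher from compound 2 to compound 3 (within the scatter) and as a number 2.9 percentage points higher from compound 1 to compound 3 (within the scatter). The read-out therefore does not separate 3-fluorophenyl from either 4-(trifluoromethoxy)phenyl or 2-fluorophenyl, so neither the 7 versus 11 heavy atoms nor the difference between the 2-fluoro and 3-fluoro names registers here. Nothing available explains this result.

All three compounds carry a phenyl ring at this carbon. From the compounds shown here alone, whether an amine or a carboxylic acid there would give a step beyond the scatter remains open.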